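Swapping sec-butyl for methylsulfanyl on the acylguanidine core

A few compounds are considered here, and "the series" means these few. Any claim that something is new, unique, unknown or untested is made for them only; others in the source may bear on it.

Three acylguanidines have been measured in a functional assay for inhibition of sodium/hydrogen exchanger (Oryctolagus cuniculus); a lower number here means a stronger inhibitor, a higher number a weaker inhibitor. Compound 1 `CCc1cc(Cl)c(S(C)(=O)=O)cc1C(=O)N=C(N)N` gives 63 nM. Compound 2 `Cc1c(C(=O)N=C(N)N)cc(S(C)(=O)=O)c(Cl)c1Cl` gives 29 nM. Compound 3 `CCC(C)c1cc(C)c(C(=O)N=C(N)N)cc1S(C)(=O)=O` gives 8 nM, the lowest of the three numbers; its gap to compound 2 and its wider gap to compound 1 both lie beyond the scatter of repeated measurements, so compound 3 is the strongest inhibitor among them.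

Compound 4 `CSc1cc(C)c(C(=O)N=C(N)N)cc1S(C)(=O)=O` has not yet been measured. It differs from compound 3 in one place: methylsulfanyl in place of sec-butyl on an aromatic carbon. Among the compounds with values here, nothing among the measured compounds isolates this particular exchange, so the direction of the step can only be guessed. The shared core with its methylsulfonyl group and acylguanidine is kept, and compounds 1 and 2 show that this core still inhibits when groups other than sec-butyl sit on it. The expected step is a 3.1-fold higher number from compound 3 to compound 4 (0.49 log units; beyond the scatter), a moderate weakening. A result within the scatter of compound 3 would nonetheless not be surprising. Compound 4 is therefore estimated at 25 nM, with a likely range from 8 nM to 80 nM.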

Compound 4, half-maximal inhibitory concentration: 6 nM
Compound 4: middle estimate off by 4.2-fold (0.62 log units), on the high side; measured number below the stated range.
By their numbers in this assay, from the lowest: compounds 4 and 3 (each within the scatter of the next); then compound 2; then compound 1.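

The exchange of sec-butyl for methylsulfanyl on the aromatic carbon ortho to the methylsulfonyl group, read in this assay, comes to a 1.3-fold lower number from compound 3 to compound 4 (0.12 log units; within the scatter), so the two groups cannot be told apart at this position. The group that leaves has 4 heavy atoms, all carbon, and none of them a hydrogen-bond acceptor, whereas the group that enters has 2 heavy atoms, one of them sulfur, and 1 hydrogen-bond acceptor; on this core, then, these differences in count and in atom type come without a step beyond the scatter. No measurement among those shown accounts for this match between the two groups.

The compounds shown leave open whether the same holds for groups of another kind on this aromatic carbon, such as an amine, a carboxylic acid or a chain longer than sec-butyl. They also leave open whether methylsulfanyl and sec-butyl would still match in this assay if another group, such as ethyl, took the place of the methyl group on the shared core.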